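The source may report more compounds than this note shows. Statements on the series, on what has been measured and on what is new or still open speak of the compounds shown alone.

Measured so far:
compound 1, `C[C@]1(c2ccc(O)cc2)CSc2cc(O)ccc2[C@H]1CCCCCCCCC(CCCC(F)(F)C(F)(F)F)C(=O)O`: 94%
compound 2, `C[C@]1(c2ccc(O)cc2)CSc2cc(O)ccc2[C@H]1CCCCCCCCC(CCCC(F)(F)C(F)(F)C(F)(F)C(F)(F)F)C(=O)O`: 99%
compound 3, `C[C@]1(c2ccc(O)cc2)CSc2cc(O)ccc2[C@H]1CCCCCCCCCC(CCCC(F)(F)C(F)(F)F)C(=O)O`: "not determined" (no result reported)

In a functional assay on the whole organism for antagonist activity, with Mus musculus as the target, at a dose of 30 mg/kg by the oral route (on this read-out lower numbers stand for a weaker effect and higher numbers for a stronger effect at the one dose given), compound 1 gives 94%, and compound 2 gives 99%. The change between them is 1,1,2,2,2-pentafluoroethyl in place of fluoro on a saturated chain carbon bound to two fluorine atoms and a saturated chain carbon, and the step that it made is a number 5 percentage points higher from compound 1 to compound 2 (within the scatter); the two values cannot be told apart on this read-out. Compound 3 carries a core that differs from that of compound 1, but the difference between the two cores is not broken down here, and compound 3 itself has no number in this assay. Compound 4, `C[C@]1(c2ccc(O)cc2)CSc2cc(O)ccc2[C@H]1CCCCCCCCCC(CCCC(F)(F)C(F)(F)C(F)(F)C(F)(F)F)C(=O)O`, is not yet measured. It stands to compound 3 as compound 2 stands to compound 1: the change is 1,1,2,2,2-pentafluoroethyl in place of fluoro on a saturated chain carbon bound to two fluorine atoms and a saturated chain carbon, the same change at the same kind of place. With no number for compound 3, the expectation for compound 4 rests on compound 1 and compound 2 alone, whose values sit close together near full inhibition, and on the step of a number 5 percentage points higher from compound 1 to compound 2 (within the scatter) being within the scatter. Compound 4 is therefore expected to give about 96% in this assay, estimated between 85% and 100%, provided the core of compound 3 behaves like that of compound 1, which nothing here shows.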

Compound 4, a percentage reported as inhibition, in the whole organism at one dose (the size of the read-out at that dose, not a potency): 100%
Compound 4: the middle estimate sits 4 percentage points below what was measured; measured number inside the range.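

For the compounds shown here, no step from compound 3 to compound 4 can be read: in this assay compound 3 stands as "not determined" (no result reported), while compound 4 gives 100%. No evidence on hand bears on this result. The compounds shown leave open how the core of compound 3 compares with the core of compound 1, and what 1,1,2,2,2-pentafluoroethyl in place of fluoro does on that core.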